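Methylation of the ring amine nitrogen of compound 1

A few compounds are considered here, and "the series" means these few. Any claim that something is new, unique, unknown or untested is made for them only; others in the source may bear on it.

Three compounds of the series carry a number in a functional assay on the whole organism for antagonist activity, with Mus musculus as the target, in the maximal electroshock model; a higher number here means that more compound is needed for the effect, a lower number that less compound is needed. Compound 1 `COC(=O)NC1=NC(c2ccccc2F)CN1` gives 54 mg/kg. Compound 2 `COC(=O)NC1=NC(c2ccccc2Br)CN1` gives 62 mg/kg, and compound 3 `COC(=O)NC1=NC(c2cc(F)ccc2F)CN1` gives 49 mg/kg. Compound 1 sits between the other two in number, nearest to compound 3 and furthest from compound 2, but the two steps away from it, a 1.1-fold higher number from compound 1 to compound 2 (0.06 log units; within the scatter) and a 1.1-fold lower number from compound 1 to compound 3 (0.04 log units; within the scatter), both lie within the scatter, so the three compounds are not distinguished by this assay.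

Compound 4 `COC(=O)NC1=NC(c2ccccc2F)CN1C` differs from compound 1 in one place: methyl in place of hydrogen on an amine nitrogen in a ring. Among the compounds with values here, both measured steps change a substituent on the aromatic ring and leave the five-membered ring untouched, so neither bears on this change; no measured pair alters the ring nitrogen. The expectation therefore rests on the baseline of compound 1 at 54 mg/kg alone, and the range must be wide. Compound 4 is expected at 60 mg/kg, between 28 mg/kg and 130 mg/kg, the estimated step being a 1.1-fold higher number from compound 1 to compound 4 (0.05 log units; within the scatter).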

Compound 4, dose for half-maximal effect: 74 mg/kg
For compound 4 the middle estimate is 1.2-fold (0.09 log units) below the measured one; measured number inside the range.
By their numbers in this assay, from the lowest: compounds 3, 1, 2 and 4 (each within the scatter of the next).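

The amine nitrogen in the five-membered ring now has a reading of its own, separate from the aromatic substituents: in this assay methyl in place of hydrogen there gives a 1.4-fold higher number from compound 1 to compound 4 (0.14 log units; within the scatter) and so does not separate the pair. The hydrogen on this nitrogen is therefore not required for a measurable dose in this model, and a methyl is tolerated at the resolution available. No measurement at hand accounts for the size of this step.

Going by these compounds, whether this nitrogen accepts more than a methyl stays open: an ethyl, a longer chain or an acetyl there could still give a step beyond the scatter. Also open, on these data alone, is whether methyl on this nitrogen behaves the same way with the aromatic substituents of compound 2 and compound 3, the step being read on the core of compound 1 alone.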